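Swapping the benzyl substituent on a shared core

This account rests on a few compounds, and the source may have more. Where it says the series, first, only, none or still open, it means among the compounds named here.

Compound 1 `CN1CCC[C@@H]1Cn1nc(Cc2ccc(F)cc2)c2ccccc2c1=O`: 79.4 nM in an assay for binding affinity to Alpha-1B adrenergic receptor (Homo sapiens); on this read-out lower numbers stand for stronger inhibition and higher numbers for weaker inhibition
Compound 2 `COc1cccc(Cc2nn(C[C@H]3CCCN3C)c(=O)c3ccccc23)c1`: in this assay compound 2 gives only a limit, > 1990 nM
Compound 3 `CN1CCC[C@@H]1Cn1nc(Cc2ccc(F)c(F)c2)c2ccccc2c1=O`: 316 nM

Compound 3 has the highest of the two numbers; the nearest is a 4.0-fold higher number from compound 1 to compound 3 (0.60 log units; beyond the scatter). Compound 4 `COc1ccc(Cc2nn(C[C@H]3CCCN3C)c(=O)c3ccccc23)cc1` differs from compound 3 by 4-methoxyphenyl in place of 3,4-difluorophenyl on a saturated chain carbon bound to an aromatic carbon. Among the compounds with values here, the only step that bears on it runs in the opposite direction: an at least 6.2-fold lower number from compound 2 to compound 3 (0.79 log units; beyond the scatter), where a methoxyphenyl gave way to the difluorophenyl. Reversing toward a methoxyphenyl, though with the methoxy placed differently, should therefore raise the number beyond the scatter, plausibly toward the limit seen for compound 2 (the limit of > 1990 nM in this assay, at which 1 of the 3 values shown sits). Compound 4 is expected at 1500 nM, between 400 nM and 5000 nM, an estimated step of a 4.7-fold higher number from compound 3 to compound 4 (0.68 log units; beyond the scatter).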

Compound 4, inhibition constant: 158 nM
The estimate for compound 4 lay 9.5-fold (0.98 log units) above the measured number; measured number outside the range, below it.
By their numbers in this assay, from the lowest: compounds 1, 4 and 3 (each within the scatter of the next, the first and the last beyond it). At a limit, above all of these: compound 2.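

In this assay, 4-methoxyphenyl in place of 3-methoxyphenyl gives an at least 12-fold lower number from compound 2 to compound 4 (1.10 log units; beyond the scatter), so at this place a methoxyphenyl group is not poor as such, and the 3- and 4-methoxyphenyl groups behave differently. The value of compound 2 is a limit, not a number. The 4-methoxyphenyl group also matches the fluorinated groups, since a 2.0-fold lower number from compound 3 to compound 4 (0.30 log units; within the scatter) and a 2.0-fold higher number from compound 1 to compound 4 (0.30 log units; within the scatter) both stay within the scatter.

Still open, on these data alone, is how an amine or a carboxylic acid on the phenyl ring would behave, or a longer chain linking that ring to the shared core.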